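A few compounds are considered here, and "the series" means these few. Any claim that something is new, unique, unknown or untested is made for them only; others in the source may bear on it.

Measured so far in a functional assay on A549 cells (Homo sapiens) for antiproliferative activity, read by CCK-8 assay, with a stated time of 48 h; a higher number here means a weaker inhibitor, a lower number a stronger inhibitor:
compound 1 `O=C(NC1CC1)c1cc(Oc2ccc(/C=C/c3ccccn3)cc2)ccn1`, 17300 nM
compound 2 `O=C(NC1CCCCC1)c1cc(Oc2ccc(/C=C/c3ccccn3)cc2)ccn1`, 12500 nM
compound 3 `O=C(NC1CC1)c1cc(Oc2ccc(/C=C/c3ccncc3)cc2)ccn1`, 35500 nM

The series shares one scaffold and varies two ends. Compound 1 to compound 2 is cyclohexyl in place of cyclopropyl on an amide-type nitrogen; this gives a 1.4-fold lower number from compound 1 to compound 2 (0.14 log units; within the scatter). Compound 1 to compound 3 is pyridin-4-yl in place of pyridin-2-yl on a double-bonded chain carbon bound to a double-bonded chain carbon; this gives a 2.1-fold higher number from compound 1 to compound 3 (0.31 log units; beyond the scatter). Compound 3 stands as the highest number of the three measured, with compound 1 nearest and compound 2 furthest.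

Compound 4 `O=C(NC1CCCCC1)c1cc(Oc2ccc(/C=C/c3ccncc3)cc2)ccn1` has not yet been measured. It differs from compound 3 by cyclohexyl in place of cyclopropyl on an amide-type nitrogen, the same change as from compound 1 to compound 2, and the two cores differ as described for compound 1 to compound 3. For the measured compounds named here, the one precedent for this change in this assay is a 1.4-fold lower number from compound 1 to compound 2 (0.14 log units; within the scatter), small and within scatter. On that basis the estimated step is a 1.4-fold lower number from compound 3 to compound 4 (0.15 log units; within the scatter). For compound 4 a value of 25000 nM is expected, in the range 12000 nM to 55000 nM.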

Compound 4, half-maximal inhibitory concentration: 16800 nM
Estimate against measurement, compound 4: 1.5-fold (0.17 log units) above, and the stated range covers the measured number.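

In this assay, cyclohexyl in place of cyclopropyl on an amide-type nitrogen gives a 2.1-fold lower number from compound 3 to compound 4 (0.32 log units; beyond the scatter), and this step agrees with the earlier one on the other core: the same change on two cores in this assay, a 1.4-fold lower number (0.14 log units; within the scatter) from compound 1 to compound 2 and a 2.1-fold lower number (0.32 log units; beyond the scatter) from compound 3 to compound 4, 1.5-fold (0.18 log units) apart, within the scatter of two such steps Pyridin-4-yl in place of pyridin-2-yl gives a 1.3-fold higher number from compound 2 to compound 4 (0.13 log units; within the scatter), which also agrees with its earlier counterpart: the same change on two cores in this assay, a 2.1-fold higher number (0.31 log units; beyond the scatter) from compound 1 to compound 3 and a 1.3-fold higher number (0.13 log units; within the scatter) from compound 2 to compound 4, 1.5-fold (0.18 log units) apart, within the scatter of two such steps Both changes therefore carry between these two cores with the same direction and no detectable dependence on the core, but each rests on a single pair of steps, one beyond the scatter and one within it, so this neither fixes the size of either step nor sets a rule for other cores.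

Still open, on these data alone, is how the series responds on the amide-type nitrogen to a group other than these two rings, such as a straight butyl chain, a benzyl group or a chain ending in an amine. Equally open is the effect of pyridin-3-yl or a plain phenyl ring in place of the pyridinyl groups shown.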